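The source may hold more compounds than are shown below. What is called first, only, known or untested is meant among the compounds shown, and "the series" means these compounds.

Measured compounds in a functional assay on MCF7 cells (Homo sapiens) for antiproliferative activity, read by MTT assay, with a stated time of 72 h; on this read-out lower numbers stand for stronger inhibition and higher numbers for weaker inhibition:
- compound 1 `O=c1cc(CC(COCc2ccccc2)COCc2ccccc2)[nH]c(=O)[nH]1` gives > 100000 nM, a limit of the assay and not a number.
- compound 2 `COCn1c(CC(COCc2ccccc2)COCc2ccccc2)cc(=O)[nH]c1=O` gives > 100000 nM, again a limit and not a number.
- compound 3 `COCn1c(=O)[nH]c(CC(COCc2ccccc2)COCc2ccccc2)c(C)c1=O` gives 21600 nM.

For the measured compounds named here, compound 3 carries the only number in this assay; the other two values sit at the limit of > 100000 nM in this assay, at which 2 of the 3 values shown sit. The difference between the core of compound 1 and the core of compound 3 is not broken down here.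

From compound 1 to compound 2 the change is methoxymethyl in place of hydrogen on an aromatic nitrogen; the step that the two limits leave unreadable from compound 1 to compound 2 cannot be read, since both ends are limits.

Compound 4 `COCn1c(CC(COCc2ccccc2)COCc2ccccc2)c(C)c(=O)n(COC)c1=O` is not yet measured. It differs from compound 3 by methoxymethyl in place of hydrogen on an aromatic nitrogen. Going by the values given here, this is the same kind of change as the one from compound 1 to compound 2, but the surroundings differ: in compound 4 the new group sits meta to a methoxymethyl group and meta to a methyl group, which is not so in compound 2.

Among the compounds with values here, the one measured instance of the change gives no readable size, so the expectation for compound 4 rests only on compound 3 with 21600 nM as the starting point and carries wide uncertainty. The step from compound 3 to compound 4 is estimated at a 1.9-fold higher number from compound 3 to compound 4 (0.27 log units; within the scatter). Compound 4 is expected to give about 40000 nM, between 10000 nM and 150000 nM, with a real chance that only a limit is returned.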

Compound 4, half-maximal inhibitory concentration: 400 nM
For compound 4 the middle estimate is 100-fold (2.00 log units) above the measured one; the measured number lies below the stated range.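

On the core of compound 3, methoxymethyl in place of hydrogen on an aromatic nitrogen gives a large step in this assay: a 54-fold lower number from compound 3 to compound 4 (1.73 log units; beyond the scatter). The same change on the core of compound 1 cannot be read, so the two cores allow no comparison of step size, because compound 1 and compound 2 both stand at a limit and not at a number: the limit of > 100000 nM in this assay, at which 2 of the 4 values shown sit. The change can therefore pay where the new group sits meta to a methoxymethyl group and meta to a methyl group, but this single readable pair does not show that those neighbours are required or that the step carries over to other cores.

Still open, on these data alone, is whether the step belongs to methoxymethyl itself or would also appear on the same nitrogen with a methyl group, a longer chain such as ethoxymethyl, or a chain ending in an amine. Also open, as far as these compounds go, is how the step would hold on a core carrying the methyl group without the methoxymethyl group, or the reverse.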